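The source may hold more compounds than are shown below. What is called first, only, known or untested is meant among the compounds shown, and "the series" means these compounds.

Three compounds share one core, an ester-bearing pyrazole that carries a coumarin on one side and an aryl on its nitrogen. Compound 1 `CCOC(=O)c1c(-c2cc3ccccc3oc2=O)nn(-c2cccc(C)c2)c1C(=O)OCC` carries an unsubstituted coumarin and a 3-methylphenyl; in a functional assay on DU-145 cells (Homo sapiens) for cytotoxicity, read by MTT assay, with a stated time of 48 h (on this read-out lower numbers stand for stronger inhibition and higher numbers for weaker inhibition), compound 1 gives 47000 nM. Compound 2 `CCOC(=O)c1c(-c2cc3ccc(OC)cc3oc2=O)nn(-c2cccc(C)c2)c1C(=O)OCC` adds a methoxy on the coumarin, and in this assay compound 2 gives 35000 nM; the change a 1.3-fold lower number from compound 1 to compound 2 (0.13 log units; within the scatter). Compound 3 `CCOC(=O)c1c(-c2cc3ccc(OCC=C(C)C)cc3oc2=O)nn(-c2ccccc2)c1C(=O)OCC` carries a prenyloxy on the coumarin and a plain phenyl on the nitrogen, and in this assay compound 3 gives 75000 nM, a number that cannot be separated from that of compound 1 within the scatter, while its gap to compound 2 lies beyond it.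

Compound 4 `CCOC(=O)c1c(-c2cc3ccc(OCC=C(C)C)cc3oc2=O)nn(-c2cccc(C)c2)c1C(=O)OCC` differs from compound 3 by methyl in place of hydrogen on an aromatic carbon. Among the measured compounds shown here, no measured step isolates this change: compound 1 and compound 3 differ in two places at once, and the single step known, from compound 1 to compound 2, concerns the other ring and stays within the scatter. Nothing in the series therefore points to a shift in this assay beyond the scatter, and compound 4 is expected to give about 55000 nM, between 22000 nM and 140000 nM, a step of a 1.4-fold lower number from compound 3 to compound 4 (0.13 log units; within the scatter) that is estimated to stay within the scatter.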

Compound 4, half-maximal inhibitory concentration: 125000 nM
Beside the measured number, compound 4's estimate is 2.3-fold (0.36 log units) below it; low and high end bracket the measured number.
By their numbers in this assay, from the lowest: compounds 2, 1, 3 and 4 (each within the scatter of the next, the first and the last beyond it).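

Among the compounds shown here, compound 4 gives the first reading in which the methyl on the nitrogen aryl changes alone: in this assay, phenyl to 3-methylphenyl with the prenyloxy coumarin held fixed gives a 1.7-fold higher number from compound 3 to compound 4 (0.22 log units; within the scatter), so this change cannot be told from no change here. For the compounds shown here, it also gives the first single-place readings of the prenyloxy on the coumarin with the 3-methylphenyl held fixed, both modest and beyond the scatter, unlike the methoxy step: replacing hydrogen gives a 2.7-fold higher number from compound 1 to compound 4 (0.42 log units; beyond the scatter) and replacing methoxy gives a 3.6-fold higher number from compound 2 to compound 4 (0.55 log units; beyond the scatter). No measurement available for these compounds offers an explanation for these steps.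

From the compounds shown here alone, the plain phenyl appears only with the prenyloxy coumarin, so it stays open whether the methyl step would read the same with an unsubstituted or methoxy coumarin, and whether the prenyloxy step would hold with the plain phenyl. Also open, going by these compounds, is how this assay would respond to a hydroxy group or a longer chain on the coumarin, or to a carboxylic acid in place of an ethyl ester on the shared core.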